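Second chloro on the fused core of compound 3

This account rests on a few compounds, and the source may have more. Where it says the series, first, only, none or still open, it means among the compounds named here.

Measured so far:
- compound 1, `ClCc1ccc(Cn2cnc3c(Cl)ncnc32)cc1`: 2450 nM
- compound 2, `ClCc1cccc(Cn2cnc3ncnc(Cl)c32)c1`: 13800 nM
- compound 3, `ClCc1cccc(Cn2cnc3c(Cl)ncnc32)c1`: 18600 nM

These three compounds were tested in a functional assay on EKVX cells (Homo sapiens) for cytotoxicity, read by sulforhodamine B assay, with a stated time of 48 h; a lower number here means a stronger inhibitor of growth, a higher number a weaker inhibitor of growth. Compound 3 gives 18600 nM, the highest of the three numbers, so it is the weakest growth inhibitor of this small set by the numbers shown. Its nearest neighbour is compound 2 with 13800 nM, a gap that lies within the scatter of repeated measurements, so the two cannot be ranked against each other. Compound 1, with 2450 nM, stands clearly apart from compound 3, a gap beyond the scatter.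

The next compound, compound 4, `ClCc1cccc(Cn2cnc3c(Cl)nc(Cl)nc32)c1`, differs from compound 3 in one place: chloro in place of hydrogen on an aromatic carbon. The new chloro enters on an aromatic carbon of a six-membered aromatic ring with two nitrogen, between two ring nitrogen atoms, meta to the chloro group already present and meta and para to the fused ring.

Going by the values given here, no measured pair in this set shows the effect of such a second chloro, so the size of the step is open. A modest step in this assay is expected, most likely towards a somewhat lower number, but one that may not exceed the scatter. Compound 4 is expected to give 11000 nM, with a range from 4000 nM to 35000 nM, which corresponds to an estimated step of a 1.7-fold lower number from compound 3 to compound 4 (0.23 log units; within the scatter).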

Compound 4, concentration for 50% growth inhibition: 1730 nM
Compound 4: middle estimate off by 6.4-fold (0.80 log units), on the high side; the whole stated range lies above it.
By their numbers in this assay, from the lowest: compounds 4 and 1 (each within the scatter of the next); then compounds 2 and 3 (each within the scatter of the next).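

In this assay, chloro in place of hydrogen on the aromatic carbon between two ring nitrogen atoms gives an 11-fold lower number from compound 3 to compound 4 (1.03 log units; beyond the scatter) and this large step lies beyond the scatter. Going by these compounds alone, the earlier compounds had no pair differing in one place, so this is the first direct sign that the shared core responds to a change at this position. The change is small in terms of structure, only one heavy atom with no ring, no hydrogen-bond donor or acceptor and no net charge, yet it moves the number clearly, and nothing given here accounts for the size of the step.

As far as these compounds go, with only hydrogen and chloro seen at this carbon, it remains open whether an amine, a methoxy group or a longer chain there would lower the number as well, or raise it. From the compounds shown here alone, it also remains open whether the same chloro would bring a step of similar size when added to compound 1 or compound 2, whose side groups or core attachment differ from those of compound 3.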